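Notes on chain extension at the ring amine

A few compounds are considered here, and "the series" means these few. Any claim that something is new, unique, unknown or untested is made for them only; others in the source may bear on it.

For the measured compounds named here, in a functional assay on HEK293 cells for activation of 5-hydroxytryptamine receptor 4 (Homo sapiens), read by cAMP accumulation (a lower number here means a smaller maximal response, a higher number a larger maximal response), compound 3 `CCN1CCC(NC(=O)c2cc(Cl)c(N)cc2OC)CC1` reports only a limit, > 100%; this is the point described in the limit of > 100% in this assay, at which 1 of the 3 values shown sits, and compound 3 is the one compound that sits there. Compound 1 `COc1cc(N)c(Cl)cc1C(=O)NCC1CCNCC1` gives 81%. Compound 2 `COc1ccc2[nH]cc(C(=O)NC3CCNCC3)c2c1`, built on a different core, gives 0%.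

Compound 4 `COc1cc(N)c(Cl)cc1C(=O)NC1CCN(CCCCCCCCO)CC1` is not yet measured. It differs from compound 3 by 6-hydroxyhexyl in place of hydrogen on a saturated chain carbon, two bonds along the chain from an amine nitrogen in a ring. Going by the values given here, no pair of measured compounds differing in one place is at hand, so the size of this step is open. Compound 1 and compound 3, which differ at the ring amine, both show a large response, so compound 4 is expected to stay high. Compound 4 is estimated at 95%, with a range from 70% to 115%. The expected step of a number at least 5 percentage points lower from compound 3 to compound 4 (that floor lies within the scatter) is small, within the scatter, with a downward lean.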

Compound 4, intrinsic activity: the largest response reached, in percent of the reference agonist's: > 100%
Compound 4 ended at the assay's limit (the forecaster's own chance of this, stated with the estimate: 35%); middle value at least 5 percentage points from the limit.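

Compound 3 and compound 4 both sit at a limit in this assay and no step between them can be read: the limit of > 100% in this assay, at which 2 of the 4 values shown sit.

The compounds shown leave open how far the maximal response of compound 4 lies from that of compound 3.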